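The source may hold more compounds than are shown below. What is called first, only, known or untested is meant among the compounds shown, and "the series" means these compounds.

In an assay on isolated protein for inhibition of cholesterol side-chain cleavage enzyme, mitochondrial (Bos taurus), tested at 50 ug/mL (on this read-out higher numbers stand for more inhibition at the one concentration tested (going by the name of the read-out) and lower numbers for less inhibition), compound 3 `NC(=O)CCc1ccc([N+](=O)[O-])cc1` gives 28%, the second highest of three numbers. Compound 1 `CN1C(=O)CC(C)(c2ccc(N)cc2)C1=O` gives 30%, within the scatter of compound 3. Compound 2 `CC1(c2ccc(N)cc2)CC(=O)NC1=O` gives 0%, well below both. Among the measured compounds shown here, the only step measured, a number 30 percentage points lower from compound 1 to compound 2 (beyond the scatter), concerns hydrogen in place of methyl on an amide-type nitrogen in a ring and does not touch the change studied here. Compound 4 `NC(=O)CCc1ccc(N)cc1` differs from compound 3 by amino in place of nitro on an aromatic carbon. For the measured compounds named here, no measured pair shows this change, so no shift beyond the scatter is expected: for compound 4 a step of no change at the digits printed from compound 3 to compound 4 (within the scatter) is estimated. Compound 4 is therefore expected to give about 28%, most likely between 5% and 50%.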

Compound 4, a percentage reported as inhibition, at one concentration (the size of the read-out at that concentration, not a potency): 19%
Compound 4: middle estimate off by 9 percentage points, on the high side; the range from low to high includes it.
By their numbers in this assay, from the lowest: compound 2; then compounds 4, 3 and 1 (each within the scatter of the next, the first and the last beyond it).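

In this assay the first direct test at this position, an aromatic carbon para to a group of 5 heavy atoms, gives a number 9 percentage points lower from compound 3 to compound 4 (within the scatter) with amino in place of nitro. On this single pair, the assay therefore does not separate the two groups, although they differ in size and in hydrogen-bond donors. Nothing measured here explains this result. Going by these compounds, whether a methoxy group, a carboxylic acid or plain hydrogen at this position would shift the number beyond the scatter remains open. So does whether the same change would behave alike on the core of compound 1.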